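Para methoxy on the shared core: a cytotoxicity estimate

The source may report more compounds than this note shows. Statements on the series, on what has been measured and on what is new or still open speak of the compounds shown alone.

Measured compounds:
compound 1, `CC(=O)Nc1ccc2oc(-c3ccccc3)cc(=O)c2c1`, 97000 nM
compound 2, `COc1ccccc1-c1cc(=O)c2cc(NC(C)=O)ccc2o1`, 50000 nM

In an ADME assay on THP-1 cells (Homo sapiens) for cytotoxicity, read by flow cytometry and propidium iodide staining, with a stated time of 72 h (a higher number here means a weaker inhibitor, a lower number a stronger inhibitor), compound 1 gives 97000 nM, the highest of the two numbers recorded so far. Its nearest neighbour is compound 2, which in this assay gives 50000 nM; the step of a 1.9-fold lower number from compound 1 to compound 2 (0.29 log units; within the scatter) is one methoxy in place of hydrogen on an aromatic carbon, and the two values lie within the scatter of each other, so no order between them can be claimed.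

Compound 3, `COc1ccc(-c2cc(=O)c3cc(NC(C)=O)ccc3o2)cc1`, has not yet been measured. It differs from compound 1 by methoxy in place of hydrogen on an aromatic carbon. Among the compounds with values here, the only measured step that bears on it is the one from compound 1 to compound 2, which also adds a methoxy in place of hydrogen on an aromatic carbon of the same ring, and that step stayed within the scatter. Within the data shown here, a methoxy placed para to a large group has no direct precedent here, so the expectation rests on that single step alone. Compound 3 is therefore expected to show a step of about a 1.5-fold lower number from compound 1 to compound 3 (0.17 log units; within the scatter), that is, no change beyond the scatter. The estimate for compound 3 in this assay is 65000 nM, within a range from 25000 nM to 160000 nM.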

Compound 3, half-maximal inhibitory concentration: 74000 nM
For compound 3 the middle estimate is 1.1-fold (0.06 log units) below the measured one; the range from low to high includes it.
By their numbers in this assay, from the lowest: compounds 2, 3 and 1 (each within the scatter of the next).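

In this assay, within the data shown here, methoxy in place of hydrogen, here on an aromatic carbon para to a large group, gives a 1.3-fold lower number from compound 1 to compound 3 (0.12 log units; within the scatter) and so stays within the scatter at a placement that the earlier compounds did not cover. Together with the earlier step, a 1.9-fold lower number from compound 1 to compound 2 (0.29 log units; within the scatter) on the same ring, this makes two methoxy placements that cannot be told apart from the unsubstituted ring of compound 1, and neither placement can be ranked above the other. The information available gives no measured basis for explaining these results.

What the compounds shown leave open is whether any replacement for hydrogen at this position can move the number beyond the scatter, since methoxy is the only group tested here; an amine, a carboxylic acid or a longer alkoxy chain in its place would address that question. They also leave open whether a change elsewhere on the shared core, such as replacing the acetyl group of the amide with a longer chain, would shift the number in this assay by more than these two methoxy steps do.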